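Open-chain and ring-closed anilides: allyl to phenyl on nitrogen

The source may report more compounds than this note shows. Statements on the series, on what has been measured and on what is new or still open speak of the compounds shown alone.

Measured compounds in a functional assay on CCRF-CEM cells (Homo sapiens) for cytotoxicity, read by resazurin assay, with a stated time of 48 h; on this read-out lower numbers stand for stronger inhibition and higher numbers for weaker inhibition:
compound 1, `C=CCN/C(SC)=C(/C#N)C(=O)Nc1ccc(OCC)cc1`, 18500 nM
compound 2, `CCOc1ccc(NC(=O)c2c(N)n[nH]c2Nc2ccccc2)cc1`, 4470 nM
compound 3, `C=CCNc1[nH]nc(N)c1C(=O)Nc1ccc(OCC)cc1`, 6560 nM

Compound 1 has the highest number of the three; its nearest neighbour is compound 3, with compound 2 further away, and both of those gaps lie beyond the scatter. The cores of compound 1 and compound 3 are not the same, and how they differ is not broken down here.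

Within the ring-closed pair, the change from compound 3 to compound 2 is phenyl in place of allyl on a nitrogen on an aromatic ring. The step this made was a 1.5-fold lower number from compound 3 to compound 2 (0.17 log units; within the scatter).

Compound 4, `CCOc1ccc(NC(=O)/C(C#N)=C(\Nc2ccccc2)SC)cc1`, is not yet measured. It stands to compound 1 as compound 2 stands to compound 3: the change is phenyl in place of allyl on an amine nitrogen. The surroundings differ, however. In the ring-closed pair the nitrogen sits on an aromatic ring whose other neighbours are aromatic carbon; in the open-chain pair it is an amine nitrogen whose other neighbours are a double-bonded chain carbon. So this is the same kind of change, not the same change.

Going by the values given here, the expectation for compound 4 rests on the single earlier step of a 1.5-fold lower number from compound 3 to compound 2 (0.17 log units; within the scatter), which was within the scatter. It also rests on the starting point of compound 1, which gives 18500 nM. The step from compound 1 to compound 4 is estimated at a 1.5-fold lower number from compound 1 to compound 4 (0.17 log units; within the scatter), a small shift in the same direction. Compound 4 is therefore expected to give 12500 nM in this assay, with a range estimated from 5000 nM to 32000 nM.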

Compound 4, half-maximal inhibitory concentration: 20300 nM
Compound 4: the middle estimate sits 1.6-fold (0.21 log units) below what was measured; the measured number falls inside the stated range.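

In this assay, phenyl in place of allyl on an amine nitrogen gives a 1.1-fold higher number from compound 1 to compound 4 (0.04 log units; within the scatter), a step that lies within the scatter. Set beside the earlier step on the ring-closed core, the two readings do not separate, so on these two pairs the change carries from one core to the other without a detectable difference: the same change on two cores in this assay, a 1.5-fold lower number (0.17 log units; within the scatter) from compound 3 to compound 2 and a 1.1-fold higher number (0.04 log units; within the scatter) from compound 1 to compound 4, 1.6-fold (0.21 log units) apart, within the scatter of two such steps. This shows agreement between two small steps only: neither lies beyond the scatter, so the series offers no case of a clear shift being carried from one core to another, and two pairs give no general rule for other cores or other substituents on this nitrogen.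

The compounds shown leave open how this nitrogen behaves with anything other than allyl or phenyl, such as a benzyl group, a longer alkyl chain or a phenyl ring carrying a methoxy group or a chlorine, and whether any of these would move the number beyond the scatter on either core. They also leave open what happens when the ethoxy group of the anilide, held constant throughout, gives way to another group such as an amine or a carboxylic acid.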